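Trimming the Urea Side Chain of Compound 1

The source may hold more compounds than are shown below. What is called first, only, known or untested is meant among the compounds shown, and "the series" means these compounds.

Among the measured compounds shown here, compound 1 `CCOC(=O)CNC(=O)NC1=CS(=O)(=O)O[C@@]12[C@@H](CO[Si](C)(C)C(C)(C)C)O[C@@H](n1cc(C)c(=O)n(C)c1=O)[C@@H]2O[Si](C)(C)C(C)(C)C` is the one compound of the three whose reading in a functional assay on HEL cells (Homo sapiens) for cytotoxicity, read by microscopy (a higher number here means that more compound is tolerated, a lower number that less compound is tolerated), is a plain number: compound 1 gives 16000 nM. Compound 2 `Cc1cn([C@@H]2O[C@H](CO[Si](C)(C)C(C)(C)C)[C@@]3(OS(=O)(=O)C=C3NC(=O)NC(=O)c3ccccc3)[C@H]2O[Si](C)(C)C(C)(C)C)c(=O)n(C)c1=O` reaches only a limit of this assay, >= 80000 nM. Compound 3 `Cc1cn([C@@H]2O[C@H](CO[Si](C)(C)C(C)(C)C)[C@@]3(OS(=O)(=O)C=C3NCC(=O)C(N)=O)[C@H]2O[Si](C)(C)C(C)(C)C)c(=O)n(C)c1=O` likewise reaches only a limit, >= 16000 nM. Compound 4 `CCNC(=O)NC1=CS(=O)(=O)O[C@@]12[C@@H](CO[Si](C)(C)C(C)(C)C)O[C@@H](n1cc(C)c(=O)n(C)c1=O)[C@@H]2O[Si](C)(C)C(C)(C)C` differs from compound 1 in one place: methyl in place of ethoxycarbonyl on a saturated chain carbon bound to an amide-type nitrogen. Two measured steps alter the same side chain, and both point the same way: an at least 5.0-fold higher number from compound 1 to compound 2 (0.69 log units; beyond the scatter) and a number no lower from compound 1 to compound 3 (the limit leaves the size open), so no change here has lowered the number. A smaller step in the same direction, or none beyond the scatter, is therefore expected for compound 4, with a limit again possible. The estimate for compound 4 is 25000 nM, between 8000 nM and 80000 nM; this means an expected step of a 1.6-fold higher number from compound 1 to compound 4 (0.19 log units; within the scatter).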

Compound 4, minimum cytotoxic concentration: >= 3200 nM
Compound 4 was reported as a limit; the forecaster's own chance of this, stated with the estimate: 45%; the middle value lies beyond the limit too.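

Compound 4 is reported only as a limit, so its steps from compound 1, compound 2 and compound 3 cannot be read. Going by these compounds, whether methyl in place of ethoxycarbonyl changes how much compound is tolerated remains open.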